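A Ring Methyl Repeated on a Second Core

A few compounds are considered here, and "the series" means these few. Any claim that something is new, unique, unknown or untested is made for them only; others in the source may bear on it.

Compound 1 `CC(C#CCn1ccnc1)N1CCCC1=O` and compound 2 `Cc1cncn1CC#CC(C)N1CCCC1=O` share one core and differ in a single place. In a functional assay on the whole organism for antagonist activity, with Mus musculus as the target (a higher number here means that more compound is needed for the effect, a lower number that less compound is needed), compound 1 gives 45 mg/kg, and compound 2 gives 25.4 mg/kg. The change between them is methyl in place of hydrogen on an aromatic carbon, and it made a step of a 1.8-fold lower number from compound 1 to compound 2 (0.25 log units; within the scatter), so the two values cannot be told apart with confidence.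

Compound 3 `CCOC(=O)N(C)CC#CCn1ccnc1` is built on a different core, and the difference between the two cores is not broken down here. In this assay compound 3 reaches only a limit of the assay, > 100 mg/kg, so no number is known for it. One of the three values shown sits at the limit of > 100 mg/kg in this assay, at which 1 of the 3 values shown sits.

Compound 4 `CCOC(=O)N(C)CC#CCn1cncc1C` has not yet been measured. It carries the same change that turned compound 1 into compound 2: methyl in place of hydrogen on an aromatic carbon. This change, at this same place, occurs twice among the compounds here. Because the earlier step was a 1.8-fold lower number from compound 1 to compound 2 (0.25 log units; within the scatter), the methyl is not expected to move the number far on the second core either. Because compound 3 gives only the limit > 100 mg/kg, the starting point is itself uncertain, and the step is estimated as a step that the limit leaves unreadable from compound 3 to compound 4. Compound 4 is expected to give about 120 mg/kg in this assay, estimated to lie between 50 mg/kg and 300 mg/kg, with a real chance that only a limit is reported again.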

Compound 4, dose for half-maximal effect: 30 mg/kg
The estimate for compound 4 lay 4.0-fold (0.60 log units) above the measured number; the measured number lies below the stated range.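

On the core of compound 3, methyl in place of hydrogen on an aromatic carbon gives an at least 3.3-fold lower number from compound 3 to compound 4 (0.52 log units; beyond the scatter), so here the change is large enough to stand out from the usual variation between repeated measurements. In this assay compound 3 gives > 100 mg/kg, which is a limit of the assay and not a number, so the step has a smallest possible size but no known true size. This shows that the methyl can be carried to the second core with a clear result there, but it does not show that the change has the same size on both cores, or a different one: the same change on two cores in this assay, a 1.8-fold lower number (0.25 log units; within the scatter) from compound 1 to compound 2 and an at least 3.3-fold lower number (0.52 log units; beyond the scatter) from compound 3 to compound 4; the limit leaves it open whether they differ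

The two pairs shown, one on each core, are too few to make a rule for the whole series, and they leave open whether the result would hold on a third core. They also leave open what other groups at this same place on the ring would do, for example an ethyl group or a chlorine atom, and whether either would give a lower or a higher number than methyl on these two cores.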